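Ethyl to butyl: from compound 2 to compound 4

A few compounds are considered here, and "the series" means these few. Any claim that something is new, unique, unknown or untested is made for them only; others in the source may bear on it.

This series shares one core and was tested in an ADME assay on MDBK cells (Bos taurus) for cytotoxicity, read by MTT assay; a lower number here means that less compound is tolerated, a higher number that more compound is tolerated. Compound 2 `CCC1CCC(OCCCCCCN2C[C@H](O)[C@@H](O)[C@H](O)[C@H]2CO)CC1` gives > 500000 nM, which is a limit of the assay and not a number. Compound 1 `OC[C@@H]1[C@@H](O)[C@H](O)[C@@H](O)CN1CCCCCCOc1cc(F)ccc1F` gives > 500000 nM, also a limit. Compound 3 `CC1CCC(OCCCCCCN2C[C@H](O)[C@@H](O)[C@H](O)[C@H]2CO)CC1C` gives > 500000 nM, again a limit. Compound 2 therefore has no number that separates it from the other two, and all three share one reading: the limit of > 500000 nM in this assay, at which 3 of the 3 values shown sit.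

Compound 4 `CCCCC1CCC(OCCCCCCN2C[C@H](O)[C@@H](O)[C@H](O)[C@H]2CO)CC1` differs from compound 2 by a single change: ethyl in place of hydrogen on a saturated chain carbon, two bonds along the chain from a saturated ring carbon. Read one bond further out, this is ethyl to butyl, so the group on the ring grows longer.

The measured steps that bear on this change also alter the group on the oxygen. They are a step that the two limits leave unreadable from compound 1 to compound 2 and a step that the two limits leave unreadable from compound 2 to compound 3. Neither has a size that can be read, and neither gave a number in place of a limit. Resting on a step that the two limits leave unreadable from compound 2 to compound 3, the expectation in this assay is no change beyond the scatter, and another limit is likely. The expected step is a number no higher from compound 2 to compound 4 (the limit leaves the size open). For compound 4 the estimated value is 500000 nM, with an expected range from 150000 nM to 1000000 nM.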

Compound 4, half-maximal cytotoxic concentration: 190000 nM
Compound 4: middle estimate off by 2.6-fold (0.42 log units), on the high side, within the range that was stated.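

In this assay, lengthening ethyl to butyl on the ring brings an at least 2.6-fold lower number from compound 2 to compound 4 (0.42 log units; beyond the scatter), so compound 4 gives the only actual number among the compounds shown, and less of it is tolerated. The steps among compound 1, compound 2 and compound 3 each join one limit to another and cannot be read, so they gave no sign that any change to the group on the oxygen could move this reading at all. The drop is a minimum and its true size stays open because compound 2 stands at a limit and not at a number, as most of the series does: the limit of > 500000 nM in this assay, at which 3 of the 4 values shown sit.

Going by these compounds, with only ethyl and butyl compared at this position, it remains open whether the number keeps falling as the chain grows, and a propyl group or a longer chain such as hexyl would be needed to show whether the change is gradual or sudden. On these data alone, it is equally open whether chain length alone counts, since a butyl chain ending in an amine or a carboxylic acid could give a quite different reading.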